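Pyridinyl in Place of Chlorophenyl on a Bcl-2 Acylsulfonamide

This account rests on a few compounds, and the source may have more. Where it says the series, first, only, none or still open, it means among the compounds named here.

Measured compounds:
compound 1, `COC1(Cc2cccc(Cl)c2)CCN(c2ccc(C(=O)NS(=O)(=O)c3ccc(N[C@H](CCN(C)C)CSc4ccccc4)c([N+](=O)[O-])c3)cc2)CC1`: 1.8 nM
compound 2, `CN(C)CC[C@H](CSc1ccccc1)Nc1ccc(S(=O)(=O)NC(=O)c2ccc(N3CCC(=Cc4ccccc4Cl)CC3)cc2)cc1[N+](=O)[O-]`: 0.7 nM

In an assay on isolated protein for displacement of a labelled ligand from Apoptosis regulator Bcl-2 (Homo sapiens), read by fluorescence polarization (on this read-out higher numbers stand for weaker inhibition and lower numbers for stronger inhibition), compound 2 gives 0.7 nM, the lowest of the two numbers on hand. Compound 1 gives 1.8 nM in the same assay, a higher number, and the gap between the two lies beyond the usual scatter of repeated measurements. The two compounds differ at more than one place, so the pair says nothing about any single change.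

Compound 3 `CN(C)CC[C@H](CSc1ccccc1)Nc1ccc(S(=O)(=O)NC(=O)c2ccc(N3CCC(=Cc4ccccn4)CC3)cc2)cc1[N+](=O)[O-]` is built from compound 2 by one alteration: pyridin-2-yl in place of 2-chlorophenyl on a double-bonded chain carbon bound to a double-bonded ring carbon. Among the measured compounds shown here, no measured pair in this set carries this exchange, so its effect cannot be read from the numbers already known. Both measured compounds sit at strong inhibition while sharing the rest of the structure with compound 3, and the exchange of one six-membered aromatic ring for another is expected to move the number only modestly, a 2.1-fold higher number from compound 2 to compound 3 (0.33 log units; beyond the scatter), most likely toward a slightly higher value. Compound 3 is therefore expected to give about 1.5 nM, within a range from 0.5 nM to 5 nM.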

Compound 3, inhibition constant: 46 nM
Estimate against measurement, compound 3: 31-fold (1.49 log units) below; the measured number lies above the stated range.
By their numbers in this assay, from the lowest: compound 2; then compound 1; then compound 3.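

In this assay, pyridin-2-yl in place of 2-chlorophenyl on a double-bonded chain carbon bound to a double-bonded ring carbon gives a 66-fold higher number from compound 2 to compound 3 (1.82 log units; beyond the scatter), so at this position one six-membered aromatic ring cannot stand in for the other without a large change in the number. Among the compounds shown here, the earlier compounds could not show this: compound 1 and compound 2 differ at more than one place, and this step is the first in the set to isolate a single exchange. The exchange removes the chlorine and brings in a ring nitrogen in one move, the step cannot divide the change between the two, and no measurement on hand gives a reason for it.

The compounds shown leave open whether plain phenyl, with neither the chlorine nor the ring nitrogen, would stay close to compound 2 or fall closer to compound 3. Also open, on these data alone, are whether pyridin-3-yl or pyridin-4-yl would follow pyridin-2-yl, and whether 2-fluorophenyl or 2-methylphenyl on the same carbon would hold the number of compound 2.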